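The source may hold more compounds than are shown below. What is called first, only, known or untested is meant among the compounds shown, and "the series" means these compounds.

In a functional assay for agonist activity at G protein-coupled receptor 88 (Homo sapiens), read by HTRF and cAMP accumulation (a lower number here means that less compound is needed, a higher number that more compound is needed for the effect), compound 1, with the structure `CC(C)CCCN(C(=O)[C@@H]1C[C@H]1c1ccccc1)c1ccc(-c2ccccc2)cc1`, gives only a limit of the assay, > 100 nM, and not a number. Compound 2, with the structure `CCCc1ccc(-c2ccc(N(C[C@@H](N)[C@@H](C)CC)C(=O)[C@@H]3C[C@H]3c3ccccc3)cc2)cc1`, gives 61 nM in this assay. Compound 3, with the structure `CC[C@H](C)[C@H](N)CN(C(=O)[C@@H]1C[C@H]1c1ccccc1)c1ccc(-c2ccc(Oc3ccccc3)cc2)cc1`, gives 94 nM in this assay. Compound 3 therefore has the higher of the two numbers that are known, and its nearest neighbour is compound 2; the step of a 1.5-fold higher number from compound 2 to compound 3 (0.19 log units; within the scatter) is within the scatter, so the two compounds cannot be told apart on this assay.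

Compound 4, with the structure `CC[C@H](C)[C@H](N)CN(C(=O)[C@@H]1C[C@H]1c1ccccc1)c1ccc(-c2ccc(N)cc2)cc1`, has not yet been measured. It differs from compound 3 in one place: amino in place of phenoxy on an aromatic carbon, placed on an aromatic carbon of a six-membered aromatic ring of carbon only, para to a large group. Among the compounds with values here, the only measured step at this position is a 1.5-fold higher number from compound 2 to compound 3 (0.19 log units; within the scatter), which exchanged two groups without moving the number beyond the scatter. An amino group is much smaller than either propyl or phenoxy, so that step gives only a weak guide, and the limit shown by compound 1 (the limit of > 100 nM in this assay, at which 1 of the 3 values shown sits) is a reminder that numbers in this series can rise out of range. The expected step is a 1.7-fold higher number from compound 3 to compound 4 (0.23 log units; within the scatter), a mild rise. Compound 4 is expected to give about 160 nM, with a range from 45 nM to 600 nM.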

Compound 4, half-maximal effective concentration: 320 nM
Compound 4: the middle estimate sits 2.0-fold (0.30 log units) below what was measured; low and high end bracket the measured number.
By their numbers in this assay, from the lowest: compounds 2 and 3 (each within the scatter of the next); then compound 4.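

The earlier step at this position, from propyl to phenoxy, stayed within the scatter and could have suggested that the position tolerates any change, but amino on this aromatic carbon, para to a large group, does not fit that picture. In this assay, within the data shown here, the exchange of phenoxy for amino gives a 3.4-fold higher number from compound 3 to compound 4 (0.53 log units; beyond the scatter), the first step at this position that can be told apart from repeated-measurement noise. The exchange of propyl for amino points the same way, with a 5.2-fold higher number from compound 2 to compound 4 (0.72 log units; beyond the scatter), so the amino compound needs more compound for the effect than either of the two compounds carrying a larger group, even though those two groups are quite unlike each other, one a chain and the other a ring joined through oxygen; nothing measured here bears on why this happens.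

The compounds shown leave open whether the number follows how many atoms the group carries or which atoms they are. A methoxy group, a hydroxyl group or a dimethylamino group at the same place, or a chain longer than propyl, would help separate these two readings.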